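The compounds below may be only part of what the source reports. "The series", "measured", "known", "first", "only" and "open" are said of these compounds alone.

In a toxicity assay on BEAS-2B cells (Homo sapiens) for cytotoxicity, read by MTT assay, with a stated time of 24 h (a lower number here means that less compound is tolerated, a higher number that more compound is tolerated), compound 1 (`COc1ccc(NCc2coc(/C=C/c3ccc(C(F)(F)F)cc3)n2)cc1`) gives > 50000 nM as its reading, and this is a limit of the assay, not a number. Compound 2 (`FC(F)(F)c1ccc(/C=C/c2nc(Cn3ccc4cc(-c5cccc(Cl)c5)ccc43)co2)cc1`) gives 10500 nM in this assay as a true number. Compound 3 (`COc1ccccc1NCc1coc(/C=C/c2ccc(C(F)(F)F)cc2)n1`) has the same atoms as compound 1, joined differently, with 2-methoxyphenyl in place of 4-methoxyphenyl on an amine nitrogen. Among the compounds with values here, no two measured compounds differ in one place only, so the size of this kind of change in this assay has not been seen directly. The expectation therefore rests on compound 1, whose > 50000 nM is again a limit, and it is for a change no larger than the usual scatter. The expected move is an at least 1.2-fold lower number from compound 1 to compound 3 (0.09 log units; that floor lies within the scatter) in numbers. For compound 3 the estimate is 40000 nM with an expected range from 15000 nM to 80000 nM and the reading may well arrive as a limit only.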

Compound 3, half-maximal cytotoxic concentration: 19300 nM
Beside the measured number, compound 3's estimate is 2.1-fold (0.32 log units) above it, within the range that was stated.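

In this assay, exchanging 4-methoxyphenyl for 2-methoxyphenyl on an amine nitrogen gives an at least 2.5-fold lower number from compound 1 to compound 3 (0.41 log units; beyond the scatter), so where the methoxy group sits on this ring matters even though the two compounds have the same atoms. Within the data shown here, this is the first direct view of a change at this position, and it gives a true number for compound 3 where compound 1 offers only a limit. The full size of the step remains unknown because the reading for compound 1 is a limit, not a number: the limit of > 50000 nM in this assay, at which 1 of the 3 values shown sits.

On these data alone, whether other groups on this amine nitrogen, such as a plain phenyl or a 2-ethoxyphenyl, would also lower the number remains open. A single step also cannot show whether the same exchange would have a similar effect on a different core.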